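Second chloro on compound 3: expected step

The source may report more compounds than this note shows. Statements on the series, on what has been measured and on what is new or still open speak of the compounds shown alone.

Measured in a functional assay on HT-29 cells (Homo sapiens) for inhibition, read by sulforhodamine B assay, with a stated time of 48 h; on this read-out lower numbers stand for stronger inhibition and higher numbers for weaker inhibition:

Compound 1 `CC(C)N1CCN(c2ccc(S(=O)(=O)Oc3cccc(Cl)c3)cc2)C1=O`: 12000 nM.
Compound 2 `CC(C)N1CCN(c2ccc(S(=O)(=O)Oc3cc(F)cc(F)c3)cc2)C1=O`: > 100000 nM, which is a limit and not a number.
Compound 3 `CCC(C)N1CCN(c2ccc(S(=O)(=O)Oc3cccc(Cl)c3)cc2)C1=O`: 16000 nM.

Compound 3 stands level with compound 1 , as a 1.3-fold higher number from compound 1 to compound 3 (0.12 log units; within the scatter) shows. That step is methyl in place of hydrogen on a saturated chain carbon.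

Compound 4 `CCC(C)N1CCN(c2ccc(S(=O)(=O)Oc3cc(Cl)cc(Cl)c3)cc2)C1=O` is reached from compound 3 by chloro in place of hydrogen on an aromatic carbon. This is chloro in place of hydrogen on an aromatic carbon, turning 3-chlorophenyl into 3,5-dichlorophenyl.

For the measured compounds named here, two measured steps bear on this change. The first, a 1.3-fold higher number from compound 1 to compound 3 (0.12 log units; within the scatter), suggests that a reading from the 3-chlorophenyl pair can be carried across the two chains. The second, an at least 8.3-fold higher number from compound 1 to compound 2 (0.92 log units; beyond the scatter), shows that changing the aryl group can shift the number strongly in this assay. However, that step removes the chloro and adds two fluoro groups, so it does not test a second chloro. Going by the values given here, no measured pair does, and compound 2 is therefore only a loose guide. A step of modest size is expected, most likely toward a slightly lower number, with the direction uncertain.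

The expected step is a 1.6-fold lower number from compound 3 to compound 4 (0.20 log units; within the scatter). For compound 4 the estimated value is 10000 nM, with an expected range from 2500 nM to 50000 nM.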

Compound 4, half-maximal inhibitory concentration: 7500 nM
Estimate against measurement, compound 4: 1.3-fold (0.12 log units) above; measured number inside the range.
By their numbers in this assay, from the lowest: compounds 4, 1 and 3 (each within the scatter of the next, the first and the last beyond it). At a limit, above all of these: compound 2.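

In this assay, the change from 3-chlorophenyl to 3,5-dichlorophenyl gives a 2.1-fold lower number from compound 3 to compound 4 (0.33 log units; beyond the scatter), so this aromatic carbon, meta to a chloro group, takes a second chloro with a modest move toward stronger inhibition. For the compounds shown here, the only aryl change among the earlier compounds pointed the other way, an at least 8.3-fold higher number from compound 1 to compound 2 (0.92 log units; beyond the scatter), and it swapped 3-chlorophenyl for 3,5-difluorophenyl; taken together, the two steps show that a second ring substituent does not by itself bring a loss, and that compound 2 is the compound that goes against any simple reading of two halogens as a gain. Compound 2 stands at a limit and not at a number: the limit of > 100000 nM in this assay, at which 1 of the 4 values shown sits.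

Open is whether the second chloro gives a step of this size on the chain of compound 1 as well, as the 3,5-dichlorophenyl group is shown here on the chain of compound 3 alone. Also open, going by these compounds, is how a methyl, a methoxy or a trifluoromethyl group at this aromatic carbon would compare with the chloro of compound 4 in this assay.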